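The source may hold more compounds than are shown below. What is called first, only, known or untested is meant among the compounds shown, and "the series" means these compounds.

Measured compounds in the series:
- compound 1 `CCN(CC)CCN(C)c1ccc(Nc2cc(NC3CC3)n3ncc(C#N)c3n2)cc1NC(C)=O`: in an ADME assay on cells (Hepatocyte, Rattus norvegicus) for metabolic stability (on this read-out higher numbers stand for fast clearance and lower numbers for slow clearance), compound 1 gives 27 uL/min
- compound 2 `CC(=O)Nc1cc(Nc2cc(NC3CC3)n3ncc(C#N)c3n2)ccc1NCCCO`: in this assay compound 2 gives 17 uL/min
- compound 3 `CC(=O)Nc1cc(Nc2cc(NC3CC3)n3ncc(C#N)c3n2)ccc1N1CCC[C@H](N)C1`: in this assay compound 3 gives a limit of the assay, < 1 uL/min

Compound 2 has the lowest of the two full numbers; the nearest is compound 1, with a 1.6-fold lower number from compound 1 to compound 2 (0.20 log units; within the scatter). Compound 3 sits at the assay limit, (the limit of < 1 uL/min in this assay, at which 1 of the 3 values shown sits).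

Compound 4 `CC(=O)Nc1cc(Nc2cc(NC3CC3)n3ncc(C#N)c3n2)ccc1N1CC[C@@H](N)C1` is yet to be measured. It differs from compound 2 in one place: 3-aminopyrrolidin-1-yl in place of (3-hydroxypropyl)amino on an aromatic carbon

Within the data shown here, two measured steps bear on this change. Going from the open chain to a cyclic amine on the same aromatic carbon gave an at least 17-fold lower number from compound 2 to compound 3 (1.23 log units; beyond the scatter), and the corresponding change from compound 1 gave an at least 27-fold lower number from compound 1 to compound 3 (1.43 log units; beyond the scatter). Both are large and in the same direction, and the change to compound 4 is of the same kind, a 3-aminopyrrolidin-1-yl in place of the (3-hydroxypropyl)amino. A large step lower is therefore expected, with a fair chance that the assay again reports only a limit.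

Compound 4 is estimated at 2 uL/min, in the range 0.7 uL/min to 8 uL/min, which means an expected step of an 8.5-fold lower number from compound 2 to compound 4 (0.93 log units; beyond the scatter).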

Compound 4, intrinsic clearance in a liver preparation (reported as CLH), per the amount of preparation that the assay uses: 2.5 uL/min
The estimate for compound 4 lay 1.3-fold (0.10 log units) below the measured number; the measured number falls inside the stated range.
By their numbers in this assay, from the lowest: compound 4; then compounds 2 and 1 (each within the scatter of the next). At a limit, below all of these: compound 3.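

In this assay, the drop seen with the 3-aminopiperidin-1-yl group is not confined to that one ring: the 3-aminopyrrolidin-1-yl group, a five-membered non-aromatic ring on the same aromatic carbon, also gives a 6.8-fold lower number from compound 2 to compound 4 (0.83 log units; beyond the scatter) and an 11-fold lower number from compound 1 to compound 4 (1.03 log units; beyond the scatter). Ring size at this position also registers, with an at least 2.5-fold higher number from compound 3 to compound 4 (0.39 log units; beyond the scatter), so among the two cyclic amines shown, the five-membered ring is the one that gives a full number. Compound 3 gives < 1 uL/min, which is a limit and not a number, so that step between the two rings is a bound and its true size stays unknown: the limit of < 1 uL/min in this assay, at which 1 of the 4 values shown sits.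

The compounds shown do not separate the effect of the ring from that of the ring amine, since the step from the (3-hydroxypropyl)amino group changes both at once; a 3-hydroxypyrrolidin-1-yl group or an open-chain (3-aminopropyl)amino group would pull them apart. As far as these compounds go, the opposite stereocentre of the 3-aminopyrrolidin-1-yl group also remains open, as does the effect of a methyl group on its ring amine.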